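The source may report more compounds than this note shows. Statements on the series, on what has been measured and on what is new or still open speak of the compounds shown alone.

Measured so far in an assay on CHO cells for displacement of a labelled ligand from adenosine receptor A3 (Homo sapiens), read by scintillation counting, with a stated time of 3 h; on this read-out higher numbers stand for weaker inhibition and lower numbers for stronger inhibition:
compound 1 `Cn1cc2c(Cl)nc(NC(=O)c3ccc(C(F)(F)F)cc3)nc2n1`, 33500 nM;
compound 2 `CC(C)(C)Cn1cc2c(Cl)nc(N)nc2n1`, given only as the assay limit > 60000 nM;
compound 3 `Cn1cc2c(Cl)nc(N)nc2n1`, given only as the assay limit > 100000 nM.

Going by the values given here, compound 1 is the only one with a number. The difference between the core of compound 1 and the core of compound 3 is not broken down here. The change tert-butyl in place of hydrogen on a saturated chain carbon bound to an aromatic nitrogen gives the step that the two limits leave unreadable from compound 3 to compound 2, which cannot be read because the limit of > 100000 nM in this assay, at which 1 of the 3 values shown sits, and the limit of > 60000 nM in this assay, at which 1 of the 3 values shown sits, are where compound 3 and compound 2 sit.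

Compound 4 `CC(C)(C)Cn1cc2c(Cl)nc(NC(=O)c3ccc(C(F)(F)F)cc3)nc2n1` carries the same change as compound 1, (tert-butyl in place of hydrogen on a saturated chain carbon bound to an aromatic nitrogen). The measured step gives no size to lean on, so the expected step of a 1.7-fold lower number from compound 1 to compound 4 (0.22 log units; within the scatter) from compound 1 is kept small, resting on compound 1 at 33500 nM. Compound 4 is thus estimated at 20000 nM in this assay, expected between 5000 nM and 70000 nM.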

Compound 4, inhibition constant: 6600 nM
Estimate against measurement, compound 4: 3.0-fold (0.48 log units) above; the measured number falls inside the stated range.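

In this assay, tert-butyl in place of hydrogen on a saturated chain carbon bound to an aromatic nitrogen gives a 5.1-fold lower number from compound 1 to compound 4 (0.71 log units; beyond the scatter), on the core carrying the amide. This is a single pair on a single core, so it sets the size of the change there and nowhere else. The same change from compound 3 to compound 2 cannot be read, both values being assay limits, so carrying it from one core to the other is neither shown nor ruled out.

Open, as far as these compounds go, is whether a longer unbranched chain at this place gives a step of similar size. Also open, from the compounds shown here alone, is what an amine or a carboxylic acid on that chain would do.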